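The source may report more compounds than this note shows. Statements on the series, on what has been measured and on what is new or still open speak of the compounds shown alone.

Measured in a functional assay on T47D cells (Homo sapiens) for cytotoxicity, read by CCK-8 assay and cell counting, with stated times of 4 h and 2 days; a lower number here means a stronger inhibitor, a higher number a weaker inhibitor:
compound 1 `Oc1cccc(-c2cc(-c3cccc(Cl)c3)cc(-c3ccccc3)n2)c1`: 680 nM
compound 2 `Oc1cccc(-c2cc(-c3ccc(Cl)cc3)cc(-c3ccco3)n2)c1`: 680 nM
compound 3 `Oc1cccc(-c2cc(-c3ccc(Cl)cc3)cc(-c3ccsc3)n2)c1`: 680 nM

In this assay, compound 3 stands level with compounds 1 and 2 at the digits available, so the three values give no order.

The next compound is compound 4 `Oc1cccc(-c2cc(-c3ccc(Cl)cc3)cc(-c3ccccc3)n2)c1`, where phenyl takes the place of thiophen-3-yl on an aromatic carbon, next to the ring nitrogen: phenyl in place of thiophen-3-yl on an aromatic carbon.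

Going by the values given here, one measured step bears on this directly, since it changes the same place. Replacing furan-2-yl with thiophen-3-yl gives no change at the digits printed from compound 2 to compound 3 (within the scatter), a step within the scatter. Compound 1, which also holds a phenyl group, gives 680 nM, so phenyl on the shared core is at least compatible with a value of this size. Among the compounds with values here, no measured step has phenyl entering at this place with the rest of the structure held fixed, so the basis is narrow and the range has to stay wide.

No step beyond the scatter and no particular direction is expected here, and the estimated change is no change at the digits printed from compound 3 to compound 4 (within the scatter). For compound 4 the expected value is 680 nM, with an estimated range from 280 nM to 1600 nM.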

Compound 4, half-maximal inhibitory concentration: 680 nM
Estimate against measurement, compound 4: no gap at the digits printed; measured number inside the range.
By their numbers in this assay, from the lowest: compounds 1, 2, 3 and 4 (each within the scatter of the next).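

In this assay, the phenyl group on the aromatic carbon next to the ring nitrogen gives no change at the digits printed from compound 3 to compound 4 (within the scatter), and against furan-2-yl at the same place it gives no change at the digits printed from compound 2 to compound 4 (within the scatter), so the six-membered aromatic ring of carbon only now reads alike with both five-membered aromatic rings on an otherwise fixed structure. Compound 4 also opens a second place to reading: 4-chlorophenyl in place of 3-chlorophenyl gives no change at the digits printed from compound 1 to compound 4 (within the scatter), so the two chlorophenyl groups cannot be told apart here, at least with phenyl held next to the ring nitrogen. No measurement bearing on the reason for these matching numbers is at hand.

Every group shown at the place next to the ring nitrogen is an unsubstituted aromatic ring, so it remains open whether an amine, a carboxylic acid or a longer alkyl chain there would give a step beyond the scatter. The 3-hydroxyphenyl group stays the same throughout, and a methoxy group in place of its hydroxyl, or a fluorine or a methyl in place of the chlorine, would test whether those places respond at all.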